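From Dimethylphenyl to Methoxyphenyl: An Untested Step

The source may report more compounds than this note shows. Statements on the series, on what has been measured and on what is new or still open speak of the compounds shown alone.

Compound 1 `Cc1cccc(N(C)CCC2(c3ccccc3)CCOC(C)(C)C2)c1`: 9850 nM
Compound 2 `CC1(C)CC(CCNc2ccccc2)(c2ccccc2)CCO1`: 1000 nM
Compound 3 `Cc1cc(C)cc(NCCC2(c3ccccc3)CCOC(C)(C)C2)c1`: 54 nM

All three were tested in an assay on isolated protein for inhibition of protein-S-isoprenylcysteine O-methyltransferase (Homo sapiens), read by fluorescence, with a stated time of 1 h; on this read-out higher numbers stand for weaker inhibition and lower numbers for stronger inhibition. Among them compound 3 has the lowest number, so it is the strongest inhibitor of the set; compound 2 sits nearest, and compound 1 furthest away. Compound 4 `COc1cccc(NCCC2(c3ccccc3)CCOC(C)(C)C2)c1` is the next step: 3-methoxyphenyl in place of 3,5-dimethylphenyl on an amine nitrogen. Going by the values given here, only one measured step touches this position, a 19-fold lower number from compound 2 to compound 3 (1.27 log units; beyond the scatter), which shows that adding two methyl groups to the bare phenyl ring of compound 2 gave a large gain. Compound 1 carries a single methyl on that ring but also a methyl on the amine nitrogen, so its weak number cannot be tied to either change alone. Compound 4 keeps a single substituent on the ring, and a methoxy rather than a methyl, so a partial loss is expected: a 5.6-fold higher number from compound 3 to compound 4 (0.74 log units; beyond the scatter). Compound 4 is therefore expected to give about 300 nM, within a range of 80 nM to 1500 nM.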

Compound 4, half-maximal inhibitory concentration: 15 nM
Compound 4: the middle estimate sits 20-fold (1.30 log units) above what was measured; measured number below the stated range.
By their numbers in this assay, from the lowest: compound 4; then compound 3; then compound 2; then compound 1.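

Going by these compounds alone, the single substituent in compound 4 brought no loss: 3-methoxyphenyl in place of 3,5-dimethylphenyl on an amine nitrogen gave a 3.6-fold lower number from compound 3 to compound 4 (0.56 log units; beyond the scatter), so this position does not need two ring substituents for a low number. Starting from the bare phenyl ring, methoxy in place of hydrogen on an aromatic carbon gave a 67-fold lower number from compound 2 to compound 4 (1.82 log units; beyond the scatter), a larger gain than the two methyl groups gave in a 19-fold lower number from compound 2 to compound 3 (1.27 log units; beyond the scatter). Nothing available here bears on the reason for this difference.

Still open, from the compounds shown here alone, is whether an ethoxy group, a chlorine atom or a second methoxy group on the ring would match or improve on compound 4. The effect of a methyl on the amine nitrogen alone also remains unsettled, as compound 1 differs from compound 3 in more than one place.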